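This account rests on a few compounds, and the source may have more. Where it says the series, first, only, none or still open, it means among the compounds named here.

Compound 1, `CCOC(=O)C1=CCCCC1S(=O)(=O)Cc1ccc(Cl)cc1F`, is the starting point of this comparison. Among the measured compounds shown here, in a functional assay on RAW264.7 cells (Mus musculus), read by fluorescence (on this read-out higher numbers stand for weaker inhibition and lower numbers for stronger inhibition), compound 1 gives 104 nM, and it is the only compound of the pair with a single clean number in this assay. The related compound 2, `CCOC(=O)C1=CCCCC1S(=O)(=O)Cc1ccccc1Cl`, has repeated entries in this assay, and they are far apart: compound 2 gives 14 nM; 1200 nM; 11 nM (3 entries), which is shown by the several entries of compound 2 in this assay, 14 nM; 1200 nM; 11 nM (3 entries) and means that no single value can be attached to it with confidence.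

The compound still to be measured is compound 3, `CCOC(=O)C1=CCCCC1S(=O)(=O)Cc1ccc(Cl)cc1Cl`. Its difference from compound 1 is chloro in place of fluoro on an aromatic carbon. For the measured compounds named here, no pair of measured compounds shows this exact change, so the size of the step has to be guessed. Halogen swaps of this kind on an aromatic ring usually shift this assay only modestly, so a small step in the direction of stronger inhibition, or none beyond the scatter, is expected from compound 1 to compound 3, a 1.7-fold lower number from compound 1 to compound 3 (0.24 log units; within the scatter). Compound 3 is therefore estimated at 60 nM, within a range from 15 nM to 300 nM.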

Compound 3, half-maximal inhibitory concentration: 60 nM
Compound 3: the middle estimate sits on the measured number at the digits printed; the range from low to high includes it.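

Among the compounds shown here, compound 1 and compound 3 give the first readable step in this set, a measured size for changing one halogen on the aromatic carbon ortho to a large group. In this assay, the change gives a 1.7-fold lower number from compound 1 to compound 3 (0.24 log units; within the scatter). For this pair, then, fluoro and chloro at this position cannot be told apart on this read-out, so the swap has no effect here that can be distinguished from ordinary repeat-to-repeat variation. No step involving compound 2 can be read, because its entries lie too far apart to give one value: the several entries of compound 2 in this assay, 14 nM; 1200 nM; 11 nM (3 entries)

From the compounds shown here alone, only two halogens are compared at this position, so it remains open whether a different kind of group there, such as a methoxy group, a nitrile or an amine, would leave the number similarly unchanged. The compounds shown also give no readable step for a change elsewhere on the shared core, such as a carboxylic acid, and this single pair cannot serve as a rule for halogen swaps at other positions.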